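Changing the Hydrazone End of Compound 1

The source may report more compounds than this note shows. Statements on the series, on what has been measured and on what is new or still open speak of the compounds shown alone.

Three measured compounds share one core. In a functional assay on MKN-45 cells (Homo sapiens) for cytotoxicity, read by MTT assay, with a stated time of 72 h (a higher number here means a weaker inhibitor, a lower number a stronger inhibitor), compound 1 `CN(C)CCn1cnnc1-c1cc(Oc2ccc(NC(=O)N/N=C/c3c(O)ccc4ccccc34)cc2F)ccn1` gives 2020 nM, the lowest of the two numbers shown. Compound 3 `Cn1cnnc1-c1cc(Oc2ccc(NC(=O)N/N=C/c3ccccc3)cc2F)ccn1` gives 7610 nM in this assay. Compound 2 `Cn1ncnc1-c1cc(Oc2ccc(NC(=O)N/N=C/c3ccccc3)cc2F)ccn1` gives a value that is only an assay limit, > 100000 nM. Among the compounds with values here, the single measured step, an at least 13-fold lower number from compound 2 to compound 3 (1.11 log units; beyond the scatter), concerns a different part of the molecule and says nothing about the hydrazone end. Compound 4 `COc1cc(/C=N/NC(=O)Nc2ccc(Oc3ccnc(-c4nncn4CCN(C)C)c3)c(F)c2)cc(OC)c1OC` differs from compound 1 exactly there: 3,4,5-trimethoxyphenyl in place of 2-hydroxynaphthalen-1-yl on a carbon with a double bond to nitrogen. Within the data shown here, no measured step bears on this change, so the expectation is loosely held. The estimate for compound 4 is 5000 nM, spanning 1000 nM to 30000 nM, which means an expected step of a 2.5-fold higher number from compound 1 to compound 4 (0.39 log units; beyond the scatter) of modest size toward a higher number.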

Compound 4, half-maximal inhibitory concentration: 2900 nM
Beside the measured number, compound 4's estimate is 1.7-fold (0.24 log units) above it; the range from low to high includes it.
By their numbers in this assay, from the lowest: compounds 1 and 4 (each within the scatter of the next); then compound 3. At a limit, above all of these: compound 2.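

In this assay, within the data shown here, the step at the hydrazone end reads a 1.4-fold higher number from compound 1 to compound 4 (0.16 log units; within the scatter) and shows what the earlier compounds could not: on a carbon with a double bond to nitrogen, 3,4,5-trimethoxyphenyl, with one aromatic ring and no hydrogen-bond donor, gives a value within the scatter of 2-hydroxynaphthalen-1-yl, with two aromatic rings and one donor. Nothing measured here explains this result. Still open, from the compounds shown here alone, is how a group without an aromatic ring, such as morpholine, would read at this place, or an aromatic ring carrying a carboxylic acid.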